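Ester Chain Size and Calcium Channel Inhibition

A few compounds are considered here, and "the series" means these few. Any claim that something is new, unique, unknown or untested is made for them only; others in the source may bear on it.

Compound 2 `CCOC(=O)C1=C(C)NC2=C(C(=O)C(C)(C)CC2)C1c1cc([N+](=O)[O-])ccc1O` in an assay for inhibition of Voltage-dependent L-type calcium channel subunit alpha-1C (Rattus norvegicus), read by patch clamp, tested at 10 uM (a lower number here means less inhibition, a higher number more inhibition at the concentration tested (going by the name of the read-out)), gives 70%. Compound 1 `CC1=C(C(=O)OCc2ccccc2)C(c2cc([N+](=O)[O-])ccc2O)C2=C(CCC(C)(C)C2=O)N1` gives 70% in this assay, so compound 2 stands level with compound 1. Among the compounds with values here, the only step measured so far, no change at the digits printed from compound 1 to compound 2 (within the scatter), stayed within the scatter. Compound 3 `CC1=C(C(=O)OCC(C)C)C(c2cc([N+](=O)[O-])ccc2O)C2=C(CCC(C)(C)C2=O)N1` differs from compound 2 by isopropyl in place of methyl on a saturated chain carbon bound to an oxygen next to a carbonyl group. Because the step of no change at the digits printed from compound 1 to compound 2 (within the scatter) at the same place changed nothing beyond the scatter, no step beyond the scatter is expected from compound 2 to compound 3 either. The expected step is therefore no change at the digits printed from compound 2 to compound 3 (within the scatter). Compound 3 is estimated at 70%, within a range from 55% to 85%.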

Compound 3, a percentage reported as inhibition, at one concentration (the size of the read-out at that concentration, not a potency): 70%
For compound 3 middle estimate and measured number coincide at the digits printed; measured number inside the range.
By their numbers in this assay, from the lowest: compounds 1, 2 and 3 (each within the scatter of the next).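

Methyl, isopropyl and phenyl now all sit at this place, on a saturated chain carbon bound to an oxygen next to a carbonyl group, and this assay does not separate them. Isopropyl in place of methyl gives no change at the digits printed from compound 2 to compound 3 (within the scatter), and isopropyl in place of phenyl gives no change at the digits printed from compound 1 to compound 3 (within the scatter), so this third group also leaves the read-out level. Nothing available here offers an explanation for this level reading.

On these data alone, whether an amine, a carboxylic acid or a longer chain at this place would also stay level remains open.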